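Aryl Ether Variation on a Shared Enaminodione Core

A few compounds are considered here, and "the series" means these few. Any claim that something is new, unique, unknown or untested is made for them only; others in the source may bear on it.

Measured compounds:
compound 1 `CC(Nc1ccccc1Oc1ccc(Cl)cc1)=C1C(=O)CC(c2ccccc2)CC1=O` gives 250 nM in a functional assay on L1210 cells (Mus musculus) for antiproliferative activity, read by cell counting, with a stated time of 96 h; on this read-out higher numbers stand for weaker inhibition and lower numbers for stronger inhibition
compound 2 `COc1ccc(Oc2ccccc2NC(C)=C2C(=O)CC(c3ccccc3)CC2=O)cc1` gives 140 nM in this assay
compound 3 `CC(Nc1ccccc1Oc1ccccc1)=C1C(=O)CC(c2ccccc2)CC1=O` gives 86 nM in this assay

Among the three measured compounds, compound 1 carries the highest number in this assay. Its nearest neighbour is compound 2, with a 1.8-fold lower number from compound 1 to compound 2 (0.25 log units; within the scatter), a difference that stays within the scatter, while compound 3 stands furthest away, with a 2.9-fold lower number from compound 1 to compound 3 (0.46 log units; beyond the scatter). Compound 2 and compound 3 differ by a 1.6-fold lower number from compound 2 to compound 3 (0.21 log units; within the scatter), which is also within the scatter.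

Compound 4 `CC(Nc1ccccc1Oc1cccc(F)c1)=C1C(=O)CC(c2ccccc2)CC1=O` has not yet been measured. It differs from compound 1 by 3-fluorophenyl in place of 4-chlorophenyl on an oxygen on an aromatic ring.

All three measured steps alter the same aromatic ring that this change touches. Replacing chloro with methoxy left the number about where it was; replacing chloro with hydrogen lowered it modestly. Among the measured compounds shown here, no measured step puts a fluorine onto this ring or moves a substituent to a different position, so the bearing of these steps on compound 4 is indirect. Because the step of a 2.9-fold lower number from compound 1 to compound 3 (0.46 log units; beyond the scatter) shows that removing the chloro on this ring lowers the number, a modest move downward is expected for compound 4, with a 1.7-fold lower number from compound 1 to compound 4 (0.22 log units; within the scatter) as the anticipated step. The estimated value for compound 4 in this assay is 150 nM, with a plausible range from 70 nM to 350 nM.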

Compound 4, half-maximal inhibitory concentration: 330 nM
Compound 4: middle estimate off by 2.2-fold (0.34 log units), on the low side; the measured number falls inside the stated range.
By their numbers in this assay, from the lowest: compounds 3, 2, 1 and 4 (each within the scatter of the next, the first and the last beyond it).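

In this assay, putting 3-fluorophenyl in place of 4-chlorophenyl on the oxygen gives a 1.3-fold higher number from compound 1 to compound 4 (0.12 log units; within the scatter), a step within the scatter, so losing the chloro does not by itself bring the number down to that of the ring with no substituent. Fluoro in place of hydrogen on an aromatic carbon gives a 3.8-fold higher number from compound 3 to compound 4 (0.58 log units; beyond the scatter), and 3-fluorophenyl in place of 4-methoxyphenyl gives a 2.4-fold higher number from compound 2 to compound 4 (0.37 log units; beyond the scatter); both steps lie beyond the scatter, showing that this ring can respond to a single fluoro and that the earlier lowering on removing chloro does not extend to every compound lacking that atom. Nothing shown explains why the fluoro step has this size.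

Because this change alters both the halogen and its place on the ring, the compounds shown cannot separate those two contributions, and 4-fluorophenyl and 3-chlorophenyl would be the direct comparisons. They also leave open how this ring would respond to an amine, a carboxylic acid or a longer chain such as butoxy, and whether any such group could bring the number below that of compound 3.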